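The compounds below may be only part of what the source reports. "The series", "measured", "known", "first", "only" and "open" are said of these compounds alone.

Measured compounds:
compound 1 `O=C(Nc1ccc(Oc2ccnc3[nH]ccc23)cc1)c1nccc(-c2ccc(Cl)cc2)n1` — 22400 nM
compound 2 `O=C(Nc1ccc(Oc2ccnc3[nH]ccc23)cc1)c1nccc(-c2ccc(F)cc2)n1` — "not active" (no number reported)
compound 3 `COc1ccc(-c2cc(C(=O)Nc3ccc(Oc4ccnc5[nH]ccc45)cc3)ncn2)cc1` — 4410 nM

In a functional assay on A549 cells (Homo sapiens) for cytotoxicity, read by MTT assay, with a stated time of 72 h (a higher number here means a weaker inhibitor, a lower number a stronger inhibitor), compound 3 gives 4410 nM, the lower of the two numbers reported. The nearest number belongs to compound 1, which gives 22400 nM, and the gap between the two lies beyond the scatter of this assay. Compound 2 was reported as not active, without a number.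

Compound 4 `O=C(Nc1ccc(Oc2ccnc3[nH]ccc23)cc1)c1cc(-c2ccc(Br)cc2)ncn1` has not yet been measured. It differs from compound 3 in one place: bromo in place of methoxy on an aromatic carbon. Among the compounds with values here, no pair of measured compounds shows this same change on its own; compound 1 and compound 2, which carry a halogen rather than a methoxy group, also differ from compound 3 in how the amide is joined to the core, so they give no clean step.

The only hint is that the two halogen-bearing compounds, compound 1 and compound 2, sit at a higher number or give no number at all, while the methoxy-bearing compound 3 sits lowest. On that thin basis, the step from compound 3 to compound 4 is expected to be a 2.3-fold higher number from compound 3 to compound 4 (0.36 log units; beyond the scatter), that is, upward and probably beyond the scatter. Compound 4 is therefore estimated at 10000 nM in this assay, with a range from 3000 nM to 40000 nM.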

Compound 4, half-maximal inhibitory concentration: 9870 nM
Compound 4: middle estimate off by 1.0-fold (0.01 log units), on the high side; the range from low to high includes it.
By their numbers in this assay, from the lowest: compound 3; then compound 4; then compound 1.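

In this assay, within the data shown here, replacing the 4-methoxyphenyl with 4-bromophenyl gives a 2.2-fold higher number from compound 3 to compound 4 (0.35 log units; beyond the scatter), the first reading in this set of a single change with everything else held the same. It shows that the group on this aromatic carbon, para to a large group, can shift the number on its own, although only modestly, and that methoxy carries the lower number of this pair. No measurement here explains why the two groups differ, so the step records an outcome and not a mechanism.

A single pair cannot show whether methoxy is favourable in itself or bromo is unfavourable, and an unsubstituted phenyl ring would be the natural reference, while an amine, a carboxylic acid or a longer chain such as ethoxy at the same place would show how far the trend extends. From the compounds shown here alone, it also remains open whether chloro or fluoro at this place would fall close to bromo on this same core, and whether the same swap would give a similar step on the core of compound 1, where the amide is joined differently.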